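Replacing an amide with a phenyl ketone: an untested analogue

The source may report more compounds than this note shows. Statements on the series, on what has been measured and on what is new or still open speak of the compounds shown alone.

Compound 1 `CC(=O)/C(=C/c1c(-c2ccccc2)[nH]c2ccccc12)C(=O)c1ccccc1` — 2000 nM
Compound 2 `N#C/C(=C\c1c(-c2ccccc2)[nH]c2ccccc12)C(=O)Nc1ccc(Cl)cc1` — 1700 nM

In a functional assay on MT4 cells (Homo sapiens) for antiproliferative activity, read by MTT assay, with a stated time of 96 h (on this read-out higher numbers stand for an effect only at larger amounts of compound and lower numbers for an effect already at smaller amounts), compound 1 gives 2000 nM and compound 2 gives 1700 nM. Of the two numbers, that of compound 2 is the smaller, but its gap to compound 1 lies within the scatter, so the two cannot be told apart. Compound 3 `N#C/C(=C\c1c(-c2ccccc2)[nH]c2ccccc12)C(=O)c1ccccc1` differs from compound 2 in one place: phenyl in place of (4-chlorophenyl)amino on a carbonyl carbon. For the measured compounds named here, no measured pair shows this change, and the two known numbers sit close together, so no step beyond the scatter is expected in this assay. Compound 3 is therefore expected to give about 2000 nM, between 700 nM and 6000 nM. That estimate means a step of a 1.2-fold higher number from compound 2 to compound 3 (0.07 log units; within the scatter), expected to stay within the scatter.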

Compound 3, half-maximal effective concentration: 500 nM
Compound 3: the middle estimate sits 4.0-fold (0.60 log units) above what was measured, and the stated range ends above it.
By their numbers in this assay, from the lowest: compound 3; then compounds 2 and 1 (each within the scatter of the next).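

In this assay phenyl in place of (4-chlorophenyl)amino on a carbonyl carbon brings a 3.4-fold lower number from compound 2 to compound 3 (0.53 log units; beyond the scatter) and so shows that the group at this place can move the number. Compounds 1 and 2 differ in more than one place and could not show this. No evidence on the reason for this step is available here.

The change removes the nitrogen with its hydrogen and the chlorine together, so the compounds shown do not separate their contributions. Plain phenylamino or 4-chlorophenyl on this carbonyl carbon would address that, while a methyl or a longer chain there remains open as well.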